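The compounds below may be only part of what the source reports. "The series", "measured", "known", "first", "only" and "open" are said of these compounds alone.

Measured so far in an ADME assay on S9 fraction from liver (Mus musculus) for metabolic stability; on this read-out higher numbers stand for a longer-lived compound and lower numbers for a shorter-lived compound:

- compound 1 `O=[N+]([O-])c1cn2c(n1)OC[C@@H](NCc1ccc(OC(F)(F)F)cc1)C2`: > 5.83 h (a limit of the assay, not a number)
- compound 2 `O=[N+]([O-])c1cn2c(n1)SC(COCc1ccc(OCc3ccccc3)cc1)C2`: 1.12 h (a number)

Compound 1 sits at a limit of this assay (> 5.83 h), so it has no exact half-life. Among the compounds with values here, compound 2 holds the only exact number (1.12 h) and is the shorter-lived of the two.

Compound 3 `CC1(COCc2ccc(OCc3ccccc3)cc2)Cn2cc([N+](=O)[O-])nc2S1` differs from compound 2 in one place: methyl in place of hydrogen on a saturated ring carbon, next to the ring sulfur (methyl in place of hydrogen on a saturated ring carbon). Within the data shown here, no measured pair shows what such a change does here, so the starting point is compound 2 at 1.12 h, and no shift beyond the usual scatter is expected. The estimated step of a 1.1-fold higher number from compound 2 to compound 3 (0.03 log units; within the scatter) is therefore small. For compound 3 the expected half-life is 1.2 h, with an estimated range from 0.5 h to 2.8 h in this assay.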

Compound 3, half-life in the Mus musculus assay: 0.517 h
For compound 3 the middle estimate is 2.3-fold (0.37 log units) above the measured one; the measured number falls inside the stated range.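

Within the data shown here, on this saturated ring carbon, next to the ring sulfur, replacing hydrogen with methyl is not a silent change: in the Mus musculus assay the result is a 2.2-fold lower number from compound 2 to compound 3 (0.34 log units; beyond the scatter) and this is the first change in one place that can be read here. Among these compounds, it is a modest step, but the earlier compounds offered no such pair. In a physicochemical assay for solubility, read by HPLC, measured as kinetic solubility (on this read-out lower numbers stand for lower solubility and higher numbers for higher solubility), the same pair shows no change at the digits printed from compound 2 to compound 3 (within the scatter) and compound 2 reads 1.2 ug/mL and compound 3 reads 1.2 ug/mL so here the half-life differs while the solubility reading does not.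

Nothing among the data shown explains why the half-life of compound 3 is shorter. Going by these compounds, whether ethyl, hydroxymethyl or a fluorine atom on this same carbon would shorten the half-life further or restore it stays open, as does whether methyl would do the same on another core.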